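Enaminone series: effect of an added methoxy group

This account rests on a few compounds, and the source may have more. Where it says the series, first, only, none or still open, it means among the compounds named here.

Measured compounds in a functional assay on MDA-MB-231 cells (Homo sapiens) for antiproliferative activity, read by sulforhodamine B assay, with a stated time of 48 h; on this read-out higher numbers stand for weaker inhibition and lower numbers for stronger inhibition:
- compound 1 `COc1cc(C(=O)/C=C\Nc2ccc(-c3nc4cc(OC)c(OC)c(OC)c4s3)cc2C)cc([N+](=O)[O-])c1OC`: 12800 nM
- compound 2 `COc1ccc(C(=O)/C=C\Nc2ccc(-c3nc4cc(OC)c(OC)c(OC)c4s3)cc2C)cc1[N+](=O)[O-]`: 12400 nM
- compound 3 `COc1ccc2nc(-c3ccc(N/C=C\C(=O)c4ccc(OC)c([N+](=O)[O-])c4)cc3)sc2c1`: 17600 nM

Compound 1 and compound 2 share one core, compound 3 carries another; the difference between the two cores is not broken down here. Within the first core, the change from compound 2 to compound 1 is methoxy in place of hydrogen on an aromatic carbon, and in this assay it gave a 1.0-fold higher number from compound 2 to compound 1 (0.01 log units; within the scatter). Compound 3 sits with the other two values in this assay without a separable gap.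

Compound 4 `COc1ccc2nc(-c3ccc(N/C=C\C(=O)c4cc(OC)c(OC)c([N+](=O)[O-])c4)cc3)sc2c1` has not been measured. Among the compounds with values here, it differs from compound 3 by methoxy in place of hydrogen on an aromatic carbon, the same change as the one made from compound 2 to compound 1, at a place described in the same words. Since that change gave a 1.0-fold higher number from compound 2 to compound 1 (0.01 log units; within the scatter), the expected step in this assay is a 1.0-fold lower number from compound 3 to compound 4 (0.02 log units; within the scatter), resting on that single earlier step. For compound 4 the estimate in this assay is 17000 nM, expected to lie between 8000 nM and 36000 nM.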

Compound 4, half-maximal inhibitory concentration: 7610 nM
The estimate for compound 4 lay 2.2-fold (0.35 log units) above the measured number; the whole stated range lies above it.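

On the second core, methoxy in place of hydrogen gave a 2.3-fold lower number from compound 3 to compound 4 (0.36 log units; beyond the scatter) in this assay, a modest step that stands clear of the scatter on its own. Set beside the earlier step, it does not separate the two cores: the same change on two cores in this assay, a 1.0-fold higher number (0.01 log units; within the scatter) from compound 2 to compound 1 and a 2.3-fold lower number (0.36 log units; beyond the scatter) from compound 3 to compound 4, 2.4-fold (0.38 log units) apart, within the scatter of two such steps The change has so far been carried between these cores without a demonstrable difference, but two pairs fix no general size for it, and they show neither that the second core responds more strongly than the first nor that both respond alike.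

Still open, on these data alone, is how the step behaves with an amine or a carboxylic acid in place of the nitro group, which all four compounds carry. Also open, as far as these compounds go, is whether a longer chain, such as ethoxy, at the place of the added methoxy gives a step of similar size on either core.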